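This account rests on a few compounds, and the source may have more. Where it says the series, first, only, none or still open, it means among the compounds named here.

Compound 1 `Nc1cc(N)c2nc(-c3ccccc3)c(Oc3ccc(Cl)c(Cl)c3)nc2c1` is the starting point of this step. Among the compounds with values here, in a functional assay on HCT-116 cells (Homo sapiens) for inhibition, read by sulforhodamine B assay, with a stated time of 48 h (on this read-out lower numbers stand for stronger inhibition of growth and higher numbers for weaker inhibition of growth), compound 1 gives 47900 nM, the only full number recorded here, which marks it as a weak inhibitor of growth. Compound 2 `CCOC(=O)[C@H](CCC(=O)O)NC(=O)c1ccc(CNc2nc3cc(N)cc(N)c3nc2-c2ccccc2)cc1` is a related analogue with a longer side chain, and in this assay compound 2 is reported as < 100000 nM, which is a limit of the assay rather than a measured number, namely (the limit of < 100000 nM in this assay, at which 1 of the 2 values shown sits). Within the data shown here, compound 1 therefore stands alone as the single measured value, with nothing to compare it against directly.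

Compound 3 `COc1ccc(Sc2nc3cc(N)cc(N)c3nc2-c2ccccc2)cc1` differs from compound 1 in one place: (4-methoxyphenyl)sulfanyl in place of 3,4-dichlorophenoxy on an aromatic carbon. Among the measured compounds shown here, no pair of measured compounds shows what such an exchange does in this assay, so the size of the step can only be guessed. A change that swaps one aryl group for another of the same size on the shared core is expected to shift the number by no more than the usual scatter, so the step of a 1.2-fold lower number from compound 1 to compound 3 (0.08 log units; within the scatter) is expected to be small and without clear direction. Compound 3 is therefore estimated at 40000 nM, with a range from 15000 nM to 100000 nM.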

Compound 3, concentration for total growth inhibition: < 100000 nM
Compound 3: no number, only a limit; the forecaster's own chance of this, stated with the estimate: 25%; the middle value is on the limit's open side.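

In this assay compound 3 gives < 100000 nM, which is a limit of the assay and not a number, so no step from compound 1 to compound 3 can be read: the limit of < 100000 nM in this assay, at which 2 of the 3 values shown sit.

As far as these compounds go, whether (4-methoxyphenyl)sulfanyl in place of 3,4-dichlorophenoxy on the shared core changes the inhibition of growth at all, and in which direction, stays open.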